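A few compounds are considered here, and "the series" means these few. Any claim that something is new, unique, unknown or untested is made for them only; others in the source may bear on it.

Three esters of a shared core sit in a functional assay on EA.hy 926 cells (Homo sapiens) for cytotoxicity, read by MTT assay, with stated times of 24 h and 12 h, tested at 50 uM (on this read-out higher numbers stand for a stronger effect at the one concentration tested and lower numbers for a weaker effect), so far. Compound 1 `COc1ccc(/C=C/C(=O)O)c(OC(=O)c2nc(C)c(C)nc2C)c1` gives 31.6% in this assay, compound 2 `COc1cc(/C=C/C(=O)O)ccc1OC(=O)c1nc(C)c(C)nc1C` gives 49.1%, and compound 3 `COc1ccc(/C=C/C(=O)O)cc1OC(=O)c1nc(C)c(C)nc1C` gives 160%. Compound 3 stands highest of the three numbers: its nearest neighbour is compound 2, a gap beyond the scatter, and the furthest is compound 1, again beyond the scatter. Compound 4 `CCOC(=O)/C=C/c1ccc(OC)c(OC(=O)c2nc(C)c(C)nc2C)c1` is not yet measured; it differs from compound 3 by ethyl in place of hydrogen on an oxygen next to a carbonyl group. Among the compounds with values here, no pair measured so far isolates this change, so its size is unknown. The step from compound 3 to compound 4 is expected to be downward, a number 70 percentage points lower from compound 3 to compound 4 (beyond the scatter), with wide uncertainty. Compound 4 is estimated at 90% in this assay, within a range of 35% to 165%.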

Compound 4, a percentage reported as activity, at one concentration (the size of the read-out at that concentration, not a potency): 89%
Estimate against measurement, compound 4: 1 percentage points above; low and high end bracket the measured number.
By their numbers in this assay, from the lowest: compound 1; then compound 2; then compound 4; then compound 3.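

In this assay, within the data shown here, the pair gives the first reading of ethyl in place of hydrogen on an oxygen next to a carbonyl group: a large step, a number 71 percentage points lower from compound 3 to compound 4 (beyond the scatter). At this position, carboxy to ethoxycarbonyl therefore lowers the read-out on the background of compound 3, while compound 4 still gives 89%. Nothing measured here gives a reason for the step.

Open, from the compounds shown here alone, is whether the step is specific to ethyl: a methyl ester, a longer chain or an amide at this place would test that. The same change on compound 1 or compound 2 cannot be read.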